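The compounds below may be only part of what the source reports. "The series", "measured", "known", "first", "only" and "open" are said of these compounds alone.

Compound 1 `CC(C)=CCC/C(C)=C/CC/C(C)=C/CC[C@]1(C)CCc2cc(OC(=O)c3ccc(C(=O)O)cc3C(=O)O)c(C)c(C)c2O1` and compound 2 `CC(C)=CCC/C(C)=C/CC/C(C)=C/CC[C@]1(C)CCc2cc(OC(=O)/C=C\C(=O)O)c(C)c(C)c2O1` share one core and differ only in the group on a carbonyl carbon. In a functional assay on cells (+SA cell, Mus musculus) for cytotoxicity, read by MTT assay, with a stated time of 24 h (a higher number here means a weaker inhibitor, a lower number a stronger inhibitor), compound 1 gives 620 nM and compound 2 gives 2300 nM, the higher of the two numbers, which makes compound 2 the weaker inhibitor of the pair. Compound 3 `CC(C)=CCC/C(C)=C/CC/C(C)=C/CC[C@]1(C)CCc2cc(OC(=O)CC(C)CC(=O)O)c(C)c(C)c2O1` keeps the core and changes the same place: 2-(carboxymethyl)propyl in place of 2-carboxyethenyl on a carbonyl carbon. In words, 2-(carboxymethyl)propyl stands in place of 2-carboxyethenyl on a carbonyl carbon.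

For the measured compounds named here, only one measured step bears on this change: a 3.7-fold higher number from compound 1 to compound 2 (0.57 log units; beyond the scatter), modest but beyond the scatter. It shows that a swap at this place can shift the number in this assay. However, no measured compound carries the entering group, so no firm direction can be expected, and a step of similar or smaller size seems likely. The estimated step is a 1.3-fold lower number from compound 2 to compound 3 (0.11 log units; within the scatter). The expected value for compound 3 is 1800 nM, with an estimated range from 700 nM to 4500 nM.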

Compound 3, half-maximal inhibitory concentration: 19200 nM
The estimate for compound 3 lay 11-fold (1.03 log units) below the measured number; the measured number lies above the stated range.
By their numbers in this assay, from the lowest: compound 1; then compound 2; then compound 3.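

In this assay, the swap from compound 2 gives an 8.3-fold higher number from compound 2 to compound 3 (0.92 log units; beyond the scatter), a larger move than the earlier step between compounds 1 and 2 showed, and the full span at this position is a 31-fold higher number from compound 1 to compound 3 (1.49 log units; beyond the scatter). So the group on this carbonyl carbon can shift the number far more than the first pair suggested, even though all three compounds carry a carboxylic acid in that group. The entering 2-(carboxymethyl)propyl differs from 2-carboxyethenyl in both size and double bonds, and no information is available to explain the loss or to separate these two differences.

The compounds shown leave open whether an unbranched chain of the same length would behave like 2-(carboxymethyl)propyl. They also leave open what an amine in place of the carboxylic acid would do.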